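Swapping a halogen for a nitro group on the styryl ring

The compounds below may be only part of what the source reports. "The series", "measured", "known", "first", "only" and "open" are said of these compounds alone.

Measured so far:
- compound 1, `O=C(/C=C/c1cccc2ccccc12)c1cccc(NC(=O)c2cc(-c3ccncc3)n[nH]2)c1`: 72100 nM
- compound 2, `O=C(/C=C/c1ccc(Cl)cc1)c1cccc(NC(=O)c2cc(-c3ccncc3)n[nH]2)c1`: 78900 nM

Both compounds share one core and differ only in the aryl group on the double-bonded chain. In a functional assay, read by spectrophotometry, tested at 100 uM (on this read-out higher numbers stand for weaker inhibition and lower numbers for stronger inhibition), compound 1 gives 72100 nM, and compound 2 gives 78900 nM. The step of a 1.1-fold higher number from compound 1 to compound 2 (0.04 log units; within the scatter) tells that these two numbers cannot be told apart. Compound 2 therefore stands at the higher of the two numbers, but only by a margin within the scatter, so nothing about order can be read from it.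

Compound 3, `O=C(/C=C/c1ccc([N+](=O)[O-])cc1)c1cccc(NC(=O)c2cc(-c3ccncc3)n[nH]2)c1`, keeps the core and the 4-substituted phenyl of compound 2, with the change (nitro in place of chloro on an aromatic carbon). Within the data shown here, no measured step touches this position: the single step available exchanges the whole aryl group and stays within the scatter. With no guidance from the data, the expected step of a 1.1-fold lower number from compound 2 to compound 3 (0.04 log units; within the scatter) is no change beyond the scatter. Compound 3 is therefore estimated at 72000 nM, with a range from 30000 nM to 160000 nM.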

Compound 3, half-maximal inhibitory concentration: 64600 nM
Estimate against measurement, compound 3: 1.1-fold (0.05 log units) above; the range from low to high includes it.
By their numbers in this assay, from the lowest: compounds 3, 1 and 2 (each within the scatter of the next).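

At this position, on an aromatic carbon para to a large group, the direct exchange of chloro for nitro in this assay gives a 1.2-fold lower number from compound 2 to compound 3 (0.09 log units; within the scatter). Among these compounds, this is the first reading of a change at this single atom, and it shows that nitro, with its 3 heavy atoms and 2 hydrogen-bond acceptors, cannot be told apart from chloro, with 1 heavy atom and no acceptors, while the earlier step only exchanged the whole aryl group. Replacing the naphthalen-1-yl group with 4-nitrophenyl gives a 1.1-fold lower number from compound 1 to compound 3 (0.05 log units; within the scatter), so all three aryl groups now read alike, and nothing measured here offers an explanation for that sameness.

Going by these compounds, whether an amine, a carboxylic acid or a methoxy group on this same aromatic carbon would move the number beyond the scatter remains open. Also open, on these data alone, is whether a longer chain in place of the double-bonded chain carbons, or any change to the shared core, would do so, since these three compounds differ only in the aryl group.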